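The compounds below may be only part of what the source reports. "The series", "measured", "known", "first", "only" and "open" are said of these compounds alone.

Three compounds of a shared core have been run in a functional assay on HepG2 cells (Homo sapiens) for inhibition, read by CCK-8 assay, with a stated time of 48 h; a lower number here means a stronger inhibitor, a higher number a weaker inhibitor. Compound 1 `COc1ccc(C2=NN(C3=NC(c4ccccc4)CS3)C(c3cccc4ccccc34)C2)cc1` gives 8740 nM. Compound 2 `Fc1ccc(C2=NN(C3=NC(c4ccccc4)CS3)C(c3cccc4ccccc34)C2)cc1` gives 23200 nM. Compound 3 `Fc1ccc(C2=NN(C3=NC(c4ccccc4)CS3)C(c3ccc4ccccc4c3)C2)cc1` gives 26500 nM, the highest of the three numbers, though its distance from compound 2 is within the scatter.

Two changes connect these. From compound 2 to compound 1 the change is methoxy in place of fluoro on an aromatic carbon, and it gave a 2.7-fold lower number from compound 2 to compound 1 (0.42 log units; beyond the scatter). From compound 2 to compound 3 the change is naphthalen-2-yl in place of naphthalen-1-yl on a saturated ring carbon, and it gave a 1.1-fold higher number from compound 2 to compound 3 (0.06 log units; within the scatter), a step within the scatter, so the two cores are not distinguished by this assay.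

Compound 4 `COc1ccc(C2=NN(C3=NC(c4ccccc4)CS3)C(c3ccc4ccccc4c3)C2)cc1` has not yet been measured. It differs from compound 3 by methoxy in place of fluoro on an aromatic carbon, the same change already seen from compound 2 to compound 1, made here on the core of compound 3 instead of the core of compound 2. The cores differ by naphthalen-2-yl in place of naphthalen-1-yl on a saturated ring carbon. Because the change from compound 2 to compound 1 gave a 2.7-fold lower number from compound 2 to compound 1 (0.42 log units; beyond the scatter), and because the core change itself gave a 1.1-fold higher number from compound 2 to compound 3 (0.06 log units; within the scatter), a step of similar size is expected from compound 3 to compound 4, namely a 2.7-fold lower number from compound 3 to compound 4 (0.42 log units; beyond the scatter). Compound 4 is therefore estimated at 10000 nM in this assay, with a range from 4000 nM to 25000 nM, resting on a single prior instance of the change.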

Compound 4, half-maximal inhibitory concentration: 12600 nM
Beside the measured number, compound 4's estimate is 1.3-fold (0.10 log units) below it; the range from low to high includes it.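

In this assay the exchange of fluoro for methoxy, that is 4-fluorophenyl to 4-methoxyphenyl, gave a 2.1-fold lower number from compound 3 to compound 4 (0.32 log units; beyond the scatter) on the core of compound 3, and it carried over between the two cores without a measurable difference in size: the same change on two cores in this assay, a 2.7-fold lower number (0.42 log units; beyond the scatter) from compound 2 to compound 1 and a 2.1-fold lower number (0.32 log units; beyond the scatter) from compound 3 to compound 4, 1.3-fold (0.10 log units) apart, within the scatter of two such steps. The exchange of naphthalen-1-yl for naphthalen-2-yl, now on the methoxy side, gave a 1.4-fold higher number from compound 1 to compound 4 (0.16 log units; within the scatter) and so again did not distinguish the two cores, whichever of the two aromatic substituents was present: the same change on two cores in this assay, a 1.1-fold higher number (0.06 log units; within the scatter) from compound 2 to compound 3 and a 1.4-fold higher number (0.16 log units; within the scatter) from compound 1 to compound 4, 1.3-fold (0.10 log units) apart, within the scatter of two such steps. This shows that the two changes behaved independently across these four compounds, but it rests on only two instances of each, on cores that differ in a single attachment point, so it does not show that the methoxy step would hold on a more distant core, nor does it explain why the step occurs.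

The compounds shown cover only fluoro and methoxy at this aromatic carbon, which leaves open whether a hydroxyl, an amine or a longer chain such as ethoxy would follow the same direction. Also open, from the compounds shown here alone, is how far the step would carry if the naphthyl group gave way to a plain phenyl, or if the phenyl on the shared core bore a chloro or a carboxylic acid.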